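Hydroxy on the benzyl ring: cytotoxicity in the series

The source may hold more compounds than are shown below. What is called first, only, known or untested is meant among the compounds shown, and "the series" means these compounds.

Measured so far:
compound 1 `O=S(=O)(NCCNC(=S)Nc1cc(C(F)(F)F)cc(C(F)(F)F)c1)c1ccc(-c2ccccc2OCc2cccc(O)c2)s1`: > 20000 nM
compound 2 `O=[N+]([O-])c1ccc(NC(=S)NCCNS(=O)(=O)c2ccc(-c3ccccc3OCc3ccccc3)s2)cc1`: 8900 nM
compound 3 `O=S(=O)(NCCNC(=S)Nc1cc(C(F)(F)F)cc(C(F)(F)F)c1)c1ccc(-c2ccccc2OCc2ccccc2)s1`: 8500 nM

In an ADME assay on HEK-293T cells (Homo sapiens) for cytotoxicity, read by CCK-8 assay, with a stated time of 48 h (a higher number here means a weaker inhibitor, a lower number a stronger inhibitor), compound 3 gives 8500 nM. In this assay compound 2 gives 8900 nM, a number that sits within the scatter of compound 3, so the two are not ordered against each other. Compound 1 in this assay gives > 20000 nM, which is a limit of the assay and not a number. The step from compound 3 to compound 1 is hydroxy in place of hydrogen on an aromatic carbon, and it produced an at least 2.3-fold higher number from compound 3 to compound 1 (0.37 log units; beyond the scatter); its size is open-ended because of the limit of > 20000 nM in this assay, at which 1 of the 3 values shown sits.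

Compound 2 and compound 3 share the same change to be made, and the difference between their two cores is not broken down here. The unmeasured compound 4 `O=[N+]([O-])c1ccc(NC(=S)NCCNS(=O)(=O)c2ccc(-c3ccccc3OCc3cccc(O)c3)s2)cc1` is obtained from compound 2 by hydroxy in place of hydrogen on an aromatic carbon, the same change, at the same kind of place, as that from compound 3 to compound 1.

The expectation for compound 4 therefore rests on a single pair. Given an at least 2.3-fold higher number from compound 3 to compound 1 (0.37 log units; beyond the scatter), the step from compound 2 to compound 4 is expected to be a 2.8-fold higher number from compound 2 to compound 4 (0.45 log units; beyond the scatter), of about the same size or larger. Starting from 8900 nM for compound 2, compound 4 is estimated at 25000 nM in this assay.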

Compound 4, half-maximal inhibitory concentration: > 20000 nM
Compound 4 ended at the assay's limit (the forecaster's own chance of this, stated with the estimate: 60%); the middle value lies beyond the limit too.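

In this assay, hydroxy in place of hydrogen on an aromatic carbon of the benzyl ring gave an at least 2.2-fold higher number from compound 2 to compound 4 (0.35 log units; beyond the scatter), so the change moved the number upward, beyond the scatter, on both cores: the same change on two cores in this assay, an at least 2.3-fold higher number (0.37 log units; beyond the scatter) from compound 3 to compound 1 and an at least 2.2-fold higher number (0.35 log units; beyond the scatter) from compound 2 to compound 4; the limit leaves it open whether they differ

What carries over is therefore the direction and a lower bound on the size of the step, not its full size, and any influence of the core on that size stays unresolved: the limit of > 20000 nM in this assay, at which 2 of the 4 values shown sit.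

The finding rests on two matched pairs, both with the 3-hydroxybenzyl group, and it cannot be extended to other cores or to other places on the ring.

The compounds shown leave open how far the numbers of compound 1 and compound 4 lie past the limit, so a test that reaches higher concentrations would be needed to compare the two steps in size. They also leave open whether a methoxy group, an amine or a carboxylic acid in place of the hydroxy would give a step of the same direction on these two cores.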